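From 2-hydroxyphenyl to thiophen-3-yl on the shared core

The source may report more compounds than this note shows. Statements on the series, on what has been measured and on what is new or still open speak of the compounds shown alone.

In a functional assay on HUVEC cells (Homo sapiens) (on this read-out higher numbers stand for an effect only at larger amounts of compound and lower numbers for an effect already at smaller amounts), compound 1 (`Cc1c(O)c(C)c2c(c1O)C(=O)CC(c1ccccc1O)O2`) gives > 20000 nM as a limit of the assay, so it has no numerical standing. Compound 2 (`COc1ccccc1C1CC(=O)c2c(O)c(C)c(O)c(C)c2O1`) gives > 20000 nM as a limit too. Compound 3 (`COc1cc(O)ccc1C1CC(=O)c2c(O)c(C)c(O)c(C)c2O1`) gives > 20000 nM as a further limit. Within the data shown here, the whole set shows the limit of > 20000 nM in this assay, at which 3 of the 3 values shown sit, and offers no measured number so far.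

Compound 4 (`Cc1c(O)c(C)c2c(c1O)C(=O)CC(c1ccsc1)O2`) carries thiophen-3-yl in place of 2-hydroxyphenyl on a saturated ring carbon while the core of compound 1 stays unchanged.

Two measured steps stand closest: a step that the two limits leave unreadable from compound 1 to compound 2 and a step that the two limits leave unreadable from compound 2 to compound 3 are the only ones available. Neither has a readable size, and both keep a six-membered aromatic ring of carbon only on that carbon, so neither tests the exchange made in compound 4. No direction can be drawn from them, and no step beyond the scatter is expected. This expectation rests on compound 1 with > 20000 nM as its limit and on nothing finer. The expected outcome is a number no higher from compound 1 to compound 4 (the limit leaves the size open) and that step may well prove unreadable. For compound 4 the estimate is 20000 nM with an expected range from 7000 nM to 40000 nM in this assay and a good chance of another limit.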

Compound 4, half-maximal effective concentration: > 50000 nM
Compound 4: only a limit was reported (the forecaster's own chance of this, stated with the estimate: 75%); middle value at least 2.5-fold (0.39 log units) away from the limit.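

Among these compounds, compound 1 and compound 4 both stand only as limits in this assay, so no step between them can be read, and the exchange of 2-hydroxyphenyl for thiophen-3-yl has no readable size. The compounds shown leave open how the two groups compare on the shared core, and what measured number any compound in this series would give.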